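Methyl in place of hydrogen: working notes on the series

This account rests on a few compounds, and the source may have more. Where it says the series, first, only, none or still open, it means among the compounds named here.

The two parent compounds are compound 1 `COc1ccc(Cl)c(-c2nnc3sc(Cc4c[nH]c5ccc(OC)cc45)nn23)c1` and compound 2 `COc1ccc2[nH]cc(Cc3nn4c(Cc5ccc(OC)c(OC)c5)nnc4s3)c2c1`; the difference between the two cores is not broken down here. In a functional assay on the whole organism (strain Wistar Albino) for inhibition, with Rattus norvegicus as the target, read by paw edema, with a stated time of 2 h, at a dose of 20 mg/kg (a higher number here means more inhibition at the dose given (going by the name of the read-out), a lower number less inhibition), compound 1 gives 14.4% and compound 2 gives 11.6%, and these two values lie within the scatter of each other. Compound 3 `COc1ccc(Cl)c(-c2nnc3sc(Cc4c(C)[nH]c5ccc(OC)cc45)nn23)c1` is compound 1 after the change (methyl in place of hydrogen on an aromatic carbon); in this assay compound 3 gives 20%, which is a number 5.6 percentage points higher from compound 1 to compound 3 (within the scatter). Compound 4 `COc1ccc2[nH]c(C)c(Cc3nn4c(Cc5ccc(OC)c(OC)c5)nnc4s3)c2c1` is the not yet measured partner of compound 2. It differs from compound 2 by methyl in place of hydrogen on an aromatic carbon, a change described in the same place as for the first pair.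

Among the compounds with values here, only one measured instance of this change exists, so any expectation rests on it alone. Within the data shown here, the step from compound 2 to compound 4 in this assay is expected to be a number 5.4 percentage points higher from compound 2 to compound 4 (within the scatter), because a number 5.6 percentage points higher from compound 1 to compound 3 (within the scatter) is the only step of this change seen. The value of compound 4 in this assay is therefore estimated at 17%, with an expected range from 8% to 26%.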

Compound 4, a percentage reported as inhibition, in the whole organism at one dose (the size of the read-out at that dose, not a potency): 16.2%
Compound 4: the middle estimate sits 0.8 percentage points above what was measured; the measured number falls inside the stated range.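

The step here is a number 4.6 percentage points higher from compound 2 to compound 4 (within the scatter) and it can be set beside the one on the core of compound 1, with which it agrees: the same change on two cores in this assay, a number 5.6 percentage points higher (within the scatter) from compound 1 to compound 3 and a number 4.6 percentage points higher (within the scatter) from compound 2 to compound 4, 1 percentage points apart, within the scatter of two such steps. On these two cores, then, methyl in place of hydrogen on an aromatic carbon carries over with a step of similar size in this assay at the single dose and time given. This does not show that the change has a real effect, since each step on its own lies within the scatter and the agreement of two small steps would also fit no effect at all; nor does it say anything about cores beyond these two.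

The compounds shown leave open whether a group other than methyl at this place, such as ethyl, a longer chain, an amine or a carboxylic acid, would give a step beyond the scatter in this assay. They also leave open whether the two methyl compounds would keep step with their parents at other doses or times.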